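Swapping the Ethynylphenyl Group for a Cyanofluorophenyl Group

The source may hold more compounds than are shown below. What is called first, only, known or untested is meant among the compounds shown, and "the series" means these compounds.

Compound 1 `C#Cc1cccc(Nc2ncnc3cc(OC)c(OCCCN4CCNCCNCCNCC4)cc23)c1` gives 1110 nM in a functional assay on A-431 cells (Homo sapiens) for antiproliferative activity, read by MTT assay, with a stated time of 72 h; on this read-out lower numbers stand for stronger inhibition and higher numbers for weaker inhibition.
Compound 2 `COc1cc2ncnc(Nc3cccc(I)c3)c2cc1OCCCN1CCNCCNCCNCC1` gives 2540 nM in this assay.
Compound 3 `C#Cc1cccc(Nc2ncnc3cc(OC)c(OCCCN4CCNCCNCC4)cc23)c1` gives 2230 nM in this assay.

Compound 3 stands second highest of these three numbers; its gap to compound 2 and its gap to compound 1 are both within the usual scatter, so the three compounds are not clearly separated from one another. Compound 4 `COc1cc2ncnc(Nc3ccc(C#N)cc3F)c2cc1OCCCN1CCNCCNCC1` differs from compound 3 in one place: 4-cyano-2-fluorophenyl in place of 3-ethynylphenyl on a nitrogen on an aromatic ring. Among the compounds with values here, only one measured step touches the same part of the molecule, the step of a 2.3-fold higher number from compound 1 to compound 2 (0.36 log units; beyond the scatter), in which a single group on that phenyl ring was exchanged and the number rose modestly. The step of a 2.0-fold higher number from compound 1 to compound 3 (0.30 log units; within the scatter) concerns the ring on the chain instead and does not bear directly on this change. The change to compound 4 exchanges the whole phenyl group, not one substituent, so a larger rise than the modest one seen is expected, though the data give no firm anchor. For compound 4 a step of a 2.7-fold higher number from compound 3 to compound 4 (0.43 log units; beyond the scatter) is expected, giving an estimated 6000 nM with a range from 2000 nM to 18000 nM.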

Compound 4, half-maximal inhibitory concentration: 12700 nM
Compound 4: the middle estimate sits 2.1-fold (0.33 log units) below what was measured; low and high end bracket the measured number.
By their numbers in this assay, from the lowest: compounds 1, 3 and 2 (each within the scatter of the next, the first and the last beyond it); then compound 4.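

The step of a 5.7-fold higher number from compound 3 to compound 4 (0.76 log units; beyond the scatter) in this assay shows that inhibition at this place, on the nitrogen on an aromatic ring, can weaken beyond the scatter when 3-ethynylphenyl gives way to 4-cyano-2-fluorophenyl. Within the data shown here, the only earlier change at this place was iodo for ethynyl, and the step of a 2.3-fold higher number from compound 1 to compound 2 (0.36 log units; beyond the scatter) stayed smaller than the new one. So exchanging the whole phenyl group moves the number further than that single swap did, though on a different ring on the chain. Nothing measured here accounts for the rise.

The nitrile and the fluorine enter together, so a phenyl ring carrying only one of them, or a chlorine instead, would be needed to separate their shares. On these data alone, it also remains open whether the ring on the chain of compound 1 would show the same rise with 4-cyano-2-fluorophenyl.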